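Adding a Methyl Group to Compound 1

The source may hold more compounds than are shown below. What is called first, only, known or untested is meant among the compounds shown, and "the series" means these compounds.

Compound 1, `COc1cccc(C(=O)NN(C(=O)c2ccccc2Cl)C(C)(C)C)c1`, is one of three compounds built on the same core. In an assay on cells for agonist activity at ecdysone receptor (Bombyx mori), read by a luciferase reporter, with a stated time of 24 h (on this read-out higher numbers stand for an effect only at larger amounts of compound and lower numbers for an effect already at smaller amounts), compound 1 gives 52.5 nM, the highest number of the three. Compound 2, `CC(C)(C)N(NC(=O)c1ccc(Br)cc1)C(=O)c1ccccc1Cl`, gives 33.9 nM; the step of a 1.5-fold lower number from compound 1 to compound 2 (0.19 log units; within the scatter) carries 4-bromophenyl in place of 3-methoxyphenyl on a carbonyl carbon. Compound 3, `CC(C)(C)N(NC(=O)c1ccc(I)cc1)C(=O)c1ccccc1Cl`, gives 7.59 nM; the step of a 6.9-fold lower number from compound 1 to compound 3 (0.84 log units; beyond the scatter) puts 4-iodophenyl in place of 3-methoxyphenyl on a carbonyl carbon, and the step of a 4.5-fold lower number from compound 2 to compound 3 (0.65 log units; beyond the scatter) exchanges iodo for bromo on an aromatic carbon.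

Compound 4, `COc1cccc(C(=O)NN(C(=O)c2ccccc2Cl)C(C)(C)C)c1C`, keeps the methoxyphenyl of compound 1 and differs from it only by methyl in place of hydrogen on an aromatic carbon. For the measured compounds named here, none of the measured steps touches this place: all three swap the whole aromatic group on the carbonyl carbon or the halogen on that group, so a methyl entering ortho to the methoxy group has no measured counterpart here. Going by the values given here, with no step bearing on it, the expectation is that compound 4 shows a step of a 1.1-fold lower number from compound 1 to compound 4 (0.02 log units; within the scatter) that stays within the scatter, in no set direction. Compound 4 is therefore estimated at 50 nM in this assay, with a range from 15 nM to 170 nM.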

Compound 4, half-maximal effective concentration: 15.5 nM
Beside the measured number, compound 4's estimate is 3.2-fold (0.51 log units) above it; low and high end bracket the measured number.
By their numbers in this assay, from the lowest: compound 3; then compound 4; then compounds 2 and 1 (each within the scatter of the next).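

The earlier steps shown here changed the whole aromatic group on the carbonyl carbon or the halogen on that group, so they said nothing about single positions on the methoxyphenyl ring. Here, with that group kept, methyl in place of hydrogen on an aromatic carbon ortho to a methoxy group gives a 3.4-fold lower number from compound 1 to compound 4 (0.53 log units; beyond the scatter) in this assay, so this position is not silent on this read-out. One added carbon, with no ring, no charge and no hydrogen-bond donor or acceptor, is enough for a step beyond the usual scatter, yet nothing available explains how the methyl produces this effect.

The compounds shown do not tell whether this lower number is particular to methyl or would also appear with an ethyl group, a chlorine atom or an amine at the same position. They also leave open whether the same methyl would lower the number on a ring without the methoxy group, or on the halogen-bearing rings of compound 2 and compound 3.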